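Swapping 4-chlorophenyl for 4-methoxyphenyl in the cytotoxicity series

The source may hold more compounds than are shown below. What is called first, only, known or untested is meant among the compounds shown, and "the series" means these compounds.

In a functional assay on HCT-15 cells (Homo sapiens) for cytotoxicity, read by MTT assay (a lower number here means a stronger inhibitor, a higher number a weaker inhibitor), compound 1 `COc1cc2ncnc(Nc3cc(O)[nH]n3)c2cc1OC` gives < 100000 nM, which is a limit and not a number. Among the measured compounds shown here, compound 2 `COc1cc2ncnc(Nc3cc(-c4ccc(Cl)cc4)[nH]n3)c2cc1OC` gives 98200 nM, the only true number so far. The evidence is thin: the limit of < 100000 nM in this assay, at which 1 of the 2 values shown sits. Compound 3 `COc1ccc(-c2cc(Nc3ncnc4cc(OC)c(OC)cc34)n[nH]2)cc1` carries methoxy in place of chloro on an aromatic carbon, para to a large group: methoxy in place of chloro on an aromatic carbon. For the measured compounds named here, the only measured step, a step that the limit leaves unreadable from compound 1 to compound 2, offers no size to carry over. No shift beyond the scatter is therefore expected in this assay, and no firm direction. The expected step is a 1.2-fold lower number from compound 2 to compound 3 (0.09 log units; within the scatter). Compound 3 is estimated at 80000 nM, with an expected range of 30000 nM to 200000 nM.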

Compound 3, half-maximal inhibitory concentration: < 100000 nM
Compound 3 gave a limit, no number; the forecaster's own chance of this, stated with the estimate: 35%; the middle value lies beyond the limit too.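

In this assay compound 3 gives < 100000 nM, a limit and not a number, so its steps from compound 1 and from compound 2 cannot be read. From the compounds shown here alone, whether 4-methoxyphenyl in place of 4-chlorophenyl shifts the value at all, and in which direction, remains open.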